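A few compounds are considered here, and "the series" means these few. Any claim that something is new, unique, unknown or untested is made for them only; others in the source may bear on it.

Measured so far:

Compound 1, `C/N=C(\NC#N)NCCOCn1nc(-c2ccccc2)ccc1=O` — in a functional assay on the whole organism (stomach) for inhibition, with Rattus norvegicus as the target, with a stated time of 4 h (a lower number here means that less compound is needed, a higher number that more compound is needed for the effect), compound 1 gives < 82.3 mg/kg, which is a limit of the assay rather than a number.

Compound 2, `C/N=C(\NC#N)NCCCOCn1nc(-c2ccccc2)ccc1=O` — in this assay compound 2 gives < 100 mg/kg, again a limit of the assay and not a number.

Compound 2 therefore stands at a limit, as does compound 1, so its true position on the scale is not pinned down. Among the measured compounds shown here, the one measured step, a step that the two limits leave unreadable from compound 1 to compound 2, is not readable, because both ends of it are limits (the limit of < 100 mg/kg in this assay, at which 1 of the 2 values shown sits, and (the limit of < 82.3 mg/kg in this assay, at which 1 of the 2 values shown sits)).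

Compound 3, `C/N=C(\NC#N)NCCCCOCn1nc(-c2ccccc2)ccc1=O`, is not yet measured. It differs from compound 2 in this way: a group of 8 heavy atoms (4 carbon, 4 nitrogen; no ring) in place of a group of 7 heavy atoms (3 carbon, 4 nitrogen; no ring), on a saturated chain carbon, three bonds along the chain from an oxygen on a saturated carbon. For the measured compounds named here, the only measured step that bears on a change of this kind is the unreadable one from compound 1 to compound 2, so no size or direction can be taken from the data. The step from compound 2 to compound 3 is expected to be a step that the limit leaves unreadable from compound 2 to compound 3, that is nothing beyond the scatter. For compound 3 the estimated dose for half-maximal effect is 50 mg/kg, with an expected range from 10 mg/kg to 150 mg/kg, and a fair chance that the assay again reports only a limit.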

Compound 3, dose for half-maximal effect: > 100 mg/kg
Compound 3 gave a limit, no number (the forecaster's own chance of this, stated with the estimate: 60%); at least 2.0-fold (0.30 log units) between middle value and limit.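

Compound 3 gives the series its first sign of a direction, which the limits of compound 1 and compound 2 could not give. In this assay, placing the group of 8 heavy atoms, three bonds along the chain from an oxygen on a saturated carbon, gives a number no lower from compound 2 to compound 3 (the limit leaves the size open). A higher number here means that more compound is needed, so this one-carbon extension brings no gain in this assay and may carry a loss. The size of that loss stays open because compound 3 is reported only as a limit of the assay: the limit of > 100 mg/kg in this assay, at which 1 of the 3 values shown sits.

Going by these compounds, compound 1 and compound 2 both sit at limits, so the step between them still cannot be read, and it remains unknown how far the chain can grow before more compound is needed. On these data alone, whether a longer chain would need still more compound, or whether an amine at the end of the chain in place of this group would change the dose needed, also stays open.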